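This account rests on a few compounds, and the source may have more. Where it says the series, first, only, none or still open, it means among the compounds named here.

Of the compounds shown here, three built on a shared hydrazone core have been measured in a functional assay on HepG2 cells (Homo sapiens) for cytotoxicity, with a stated time of 24 h; a lower number here means a stronger inhibitor, a higher number a weaker inhibitor. Compound 1 `CC(C)(C)c1ccc(C(=O)N/N=C/c2cc(I)cc(I)c2O)cc1` gives 41600 nM. Compound 2 `O=C(N/N=C/c1cc(I)cc(I)c1O)c1ccc(I)cc1` gives 31800 nM. Compound 3 `CC(C)(C)c1ccc(C(=O)N/N=C/c2cc(I)c(O)c(I)c2)cc1` gives 45900 nM, the highest of the three numbers, although its gaps to compound 1 and to compound 2 both lie within the scatter, so none of the three can be set apart from the others on these figures.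

Compound 4 `O=C(N/N=C/c1cc(I)c(O)c(I)c1)c1ccc(Cl)cc1` has not yet been measured in this assay. It differs from compound 3 in one place: chloro in place of tert-butyl on an aromatic carbon. Among the measured compounds shown here, one measured step bears on this change, the exchange of a tert-butyl group for an iodo group on an aromatic carbon, and that step was a 1.3-fold lower number from compound 1 to compound 2 (0.12 log units; within the scatter). A chloro group is a halogen like iodo, and the exchange falls on the same kind of aromatic carbon, so a step of much the same size is expected. Because a 1.3-fold lower number from compound 1 to compound 2 (0.12 log units; within the scatter) stayed within the scatter, the expected step of a 1.1-fold lower number from compound 3 to compound 4 (0.06 log units; within the scatter) is also within the scatter, in no clear direction. Compound 4 is therefore expected to give 40000 nM in this assay, with a range from 20000 nM to 80000 nM.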

Compound 4, half-maximal inhibitory concentration: > 100000 nM
Compound 4: only a limit was reported; the forecaster's own chance of this, stated with the estimate: 10%; at least 2.5-fold (0.39 log units) between middle value and limit.
By their numbers in this assay, from the lowest: compounds 2, 1 and 3 (each within the scatter of the next). At a limit, above all of these: compound 4.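

Compound 4 gives only a limit in this assay, > 100000 nM. Even with that limit, swapping tert-butyl for chloro at this place on the ring is not a neutral change: the step is an at least 2.1-fold higher number from compound 3 to compound 4 (0.33 log units; beyond the scatter), which means a weaker inhibitor, whereas the exchange of tert-butyl for iodo on the core of compound 1 was a 1.3-fold lower number from compound 1 to compound 2 (0.12 log units; within the scatter), so a halogen in place of tert-butyl does not always leave the number within the scatter. The step gives only a minimum size, because compound 4 sits at the limit of the assay: the limit of > 100000 nM in this assay, at which 1 of the 4 values shown sits.

The two steps differ both in the halogen and in the core that carries it, so the compounds shown cannot tell whether chloro itself or the core of compound 3 sets this result apart; chloro on the core of compound 1, or iodo on the core of compound 3, would separate the two. On these data alone, it also stays open how other groups at this place would behave, such as a methoxy group, an amine or a carboxylic acid.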